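Swapping the Aryl Group on the Triazole Ring

A few compounds are considered here, and "the series" means these few. Any claim that something is new, unique, unknown or untested is made for them only; others in the source may bear on it.

Compound 3 `C=C1C(=O)[C@]23C[C@@]1(O)CC[C@H]2c1ccc(O)c(C)c1[C@@H]3Cn1cc(-c2ccccn2)nn1` carries a free hydroxyl on its aromatic ring and a pyridin-2-yl group on the triazole. In a functional assay on SW480 cells (Homo sapiens) for cytotoxicity, read by MTT assay, with a stated time of 4 days (on this read-out higher numbers stand for weaker inhibition and lower numbers for stronger inhibition), compound 3 gives 410 nM, the lowest of the two numbers shown. Compound 1 `C=C1C(=O)[C@]23C[C@@]1(O)CC[C@H]2c1ccc(OS(=O)(=O)c2ccc(C)cc2)c(C)c1[C@@H]3Cn1cc(-c2ccccn2)nn1` differs only in bearing a (4-methylphenyl)sulfonyl group on that oxygen, and in this assay compound 1 gives 1970 nM. The step of a 4.8-fold lower number from compound 1 to compound 3 (0.68 log units; beyond the scatter) shows that removing the sulfonyl group lowers the number. Compound 2 `Cc1ccc(S(=O)(=O)Oc2ccc3c(c2C)[C@H](Cn2cc(-c4ccccn4)nn2)[C@@]24CC(=O)[C@@](C)(CC[C@@H]32)C4)cc1` has a different core without the hydroxyl, and in this assay compound 2 reaches only a limit of > 20000 nM, which is the limit of > 20000 nM in this assay, at which 1 of the 3 values shown sits, rather than a number.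

Compound 4 `C=C1C(=O)[C@]23C[C@@]1(O)CC[C@H]2c1ccc(O)c(C)c1[C@@H]3Cn1cc(-c2ccc(OC)cc2)nn1` keeps the free hydroxyl of compound 3 and changes the group on the triazole: 4-methoxyphenyl in place of pyridin-2-yl on an aromatic carbon. Among the compounds with values here, none of the measured steps touches this part of the molecule; the only step, from compound 1 to compound 3, concerns the oxygen on the aromatic ring. There is therefore no measured guide, and a change no larger than the scatter is expected, so the estimated step of a 1.5-fold higher number from compound 3 to compound 4 (0.17 log units; within the scatter) is small. Compound 4 is expected to give about 600 nM in this assay, most likely between 200 nM and 2000 nM.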

Compound 4, half-maximal inhibitory concentration: 220 nM
For compound 4 the middle estimate is 2.7-fold (0.44 log units) above the measured one, within the range that was stated.
By their numbers in this assay, from the lowest: compounds 4 and 3 (each within the scatter of the next); then compound 1. At a limit, above all of these: compound 2.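

The earlier compounds shown here all carry pyridin-2-yl on the triazole, so they could say nothing about this position. Here, 4-methoxyphenyl in place of pyridin-2-yl gives a 1.9-fold lower number from compound 3 to compound 4 (0.27 log units; within the scatter) and so no real separation between the two compounds in this assay, which means that, for this pair, the ring nitrogen of pyridin-2-yl is not needed to keep a value of this size: a ring of carbon only, carrying a methoxy group, serves as well on this aromatic carbon of the triazole. Nothing measured here goes beyond this cell read-out to account for why the two groups read alike.

Two aryl groups at a single position cannot show how much change it accepts, and a plain butyl chain on the triazole, or a phenyl ring bearing an amine or a carboxylic acid in place of the methoxy group, would probe it much further. Going by these compounds, it also stays open whether 4-methoxyphenyl would read the same way on the sulfonyl-bearing oxygen of compound 1, since the swap has been seen here only alongside the free hydroxyl.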